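Moving the Bromine Atom: From Compound 1 to Compound 4

The compounds below may be only part of what the source reports. "The series", "measured", "known", "first", "only" and "open" are said of these compounds alone.

Measured so far:
Compound 1 `O=C(COc1cccc2ccccc12)N/N=C/c1ccccc1Br` — a limit of the test, not a number: >= 20 ug/mL.
Compound 2 `COc1ccc(OC)c(/C=N/NC(=O)COc2cccc3ccccc23)c1` — likewise a limit: >= 20 ug/mL.
Compound 3 `O=C(COc1cccc2ccccc12)N/N=C/c1c(O)ccc2ccccc12` — 4 ug/mL.

These three compounds were tested in an ADME assay on HEL cells (Homo sapiens) for cytotoxicity; on this read-out higher numbers stand for lower toxicity in this test and lower numbers for higher toxicity in this test. Compound 1 sits at the limit of the test, so its true value is not known as a number; in this assay compound 1 gives >= 20 ug/mL. Compound 2 sits at the same limit. Within the data shown here, compound 3 is the one compound with a number, and in this assay compound 3 gives 4 ug/mL, which is on the more toxic side. No pair of these compounds differs in one place only, so no measured step is available to lean on; what stands out is the limit of >= 20 ug/mL in this assay, at which 2 of the 3 values shown sit.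

Compound 4 `O=C(COc1cccc2ccccc12)N/N=C/c1cccc(Br)c1` has not yet been measured. Compared with compound 1 the change is 3-bromophenyl in place of 2-bromophenyl on a carbon with a double bond to nitrogen. The two compounds share every other part. With compound 1 at the limit, the step is expected to be none beyond the scatter: a number no higher from compound 1 to compound 4 (the limit leaves the size open). Compound 4 is therefore expected to give about 20 ug/mL in this assay, within 8 ug/mL to 40 ug/mL, and most likely to be reported again only as a limit.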

Compound 4, minimum cytotoxic concentration: 100 ug/mL
Compound 4: middle estimate off by 5.0-fold (0.70 log units), on the low side; the whole stated range lies below it.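

In this assay compound 1 gives >= 20 ug/mL, which is a limit and not a number, so the step to compound 4, with 3-bromophenyl in place of 2-bromophenyl, cannot be read. The compounds shown leave open how far 3-bromophenyl and 2-bromophenyl differ on this read-out, or whether they differ at all.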